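The source may report more compounds than this note shows. Statements on the series, on what has been measured and on what is new or still open speak of the compounds shown alone.

Measured so far:
compound 1 `CCOC(=O)c1c(-c2cccc(-c3ccccc3)c2)[nH]c2cc(OC(C)C)ccc2c1=O` — > 22000 nM
compound 2 `CCOC(=O)c1c(-c2cccc(OC)c2)[nH]c2cc(OC(C)C)ccc2c1=O` — > 22000 nM
compound 3 `CCOC(=O)c1c(-c2cccc(-c3ccccc3)c2)[nH]c2cc(OC)c(OC)cc2c1=O` — > 22000 nM

In an ADME assay on HEK293 cells (Homo sapiens) for cytotoxicity, read by luminescence, with a stated time of 72 h (on this read-out lower numbers stand for an effect already at smaller amounts and higher numbers for an effect only at larger amounts of compound), compound 1 gives only a limit, > 22000 nM. Compound 2 gives only a limit in this assay as well, > 22000 nM. Compound 3 likewise gives only a limit in this assay, > 22000 nM. The change methoxy in place of phenyl on an aromatic carbon gives a step that the two limits leave unreadable from compound 1 to compound 2. The difference between the core of compound 1 and the core of compound 3 is not broken down here.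

Compound 4 `CCOC(=O)c1c(-c2cccc(OC)c2)[nH]c2cc(OC)c(OC)cc2c1=O` is not yet measured. Going by the values given here, it differs from compound 3 by methoxy in place of phenyl on an aromatic carbon, the same change as the one from compound 1 to compound 2. In this assay compound 4 is expected to give 30000 nM, an estimated step that the limit leaves unreadable from compound 3 to compound 4 from compound 3. This expectation rests on a step that the two limits leave unreadable from compound 1 to compound 2 and on (the limit of > 22000 nM in this assay, at which 3 of the 3 values shown sit); a further limit rather than a number is expected.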

Compound 4, half-maximal effective concentration: > 22000 nM
Compound 4 ended at the assay's limit; the forecaster's own chance of this, stated with the estimate: 90%; the middle value lies beyond the limit too.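

No step can be read between compound 3 and compound 4, as both values are limits of the assay. The compounds shown leave open what effective concentration any of them has, and whether methoxy in place of phenyl alters it.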